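Acetyl Replaces the Urea: Expected Monoamine Oxidase A Inhibition

A few compounds are considered here, and "the series" means these few. Any claim that something is new, unique, unknown or untested is made for them only; others in the source may bear on it.

Measured compounds:
compound 1, `CCOc1cc(=O)oc2cc(OCc3cccc(Cl)c3)ccc12`: 2%
compound 2, `COCOc1cc(=O)oc2cc(OCc3cccc(Cl)c3)ccc12`: 23%
compound 3, `CCNC(=O)Nc1cc(=O)oc2cc(OCc3cccc(Cl)c3)ccc12`: 0%

In an assay on isolated protein (strain Sprague-Dawley) for inhibition of Amine oxidase [flavin-containing] A (Rattus norvegicus), read by spectrophotometry, with a stated time of 5 min, tested at 10 uM (a lower number here means less inhibition, a higher number more inhibition at the concentration tested (going by the name of the read-out)), compound 3 gives 0%, the lowest of the three numbers. Its nearest value lies within the scatter (a number 2 percentage points lower from compound 1 to compound 3 (within the scatter)), while the furthest is beyond it (a number 23 percentage points lower from compound 2 to compound 3 (beyond the scatter)). Compound 4 is `CC(=O)c1cc(=O)oc2cc(OCc3cccc(Cl)c3)ccc12`. acetyl in place of (ethylcarbamoyl)amino on an aromatic carbon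

Two measured steps exchange a group at this same aromatic carbon: a number 2 percentage points lower from compound 1 to compound 3 (within the scatter) and a number 23 percentage points lower from compound 2 to compound 3 (beyond the scatter). The step of a number 21 percentage points higher from compound 1 to compound 2 (beyond the scatter) alters a different place and bears less. Three groups at this carbon span only a modest range, so the step of a number 8 percentage points higher from compound 3 to compound 4 (within the scatter) is expected to be small, if anything upward. Compound 4 is estimated at 8%, with a range from 0% to 25%.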

Compound 4, a percentage reported as inhibition, at one concentration (the size of the read-out at that concentration, not a potency): 0%
Compound 4: middle estimate off by 8 percentage points, on the high side; low and high end bracket the measured number.
By their numbers in this assay, from the lowest: compounds 3, 4 and 1 (each within the scatter of the next); then compound 2.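

Swapping (ethylcarbamoyl)amino for acetyl, a group with fewer heavy atoms and no hydrogen-bond donors, leaves the read-out unmoved (no change at the digits printed from compound 3 to compound 4 (within the scatter)), and acetyl also sits level with ethoxy (a number 2 percentage points lower from compound 1 to compound 4 (within the scatter)). Methoxymethoxy therefore remains the only group at this aromatic carbon that stands apart from the other three (a number 23 percentage points lower from compound 2 to compound 4 (beyond the scatter)). No supporting measurement is available to explain this separation.

As far as these compounds go, whether an amine, a carboxylic acid or a longer chain with an ether oxygen at this carbon would raise the inhibition remains open.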